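Trimethoxyanilines: bromo for methyl on the benzyl ring

This account rests on a few compounds, and the source may have more. Where it says the series, first, only, none or still open, it means among the compounds named here.

Measured so far:
- compound 1, `COc1ccc(CNc2cc(OC)c(OC)c(OC)c2)cc1C`: 56800 nM
- compound 2, `C/C=C/C(=O)N(Cc1ccc(OC)c(C)c1)c1cc(OC)c(OC)c(OC)c1`: 14500 nM

Among the measured compounds shown here, compound 1 has the highest number of the two in a functional assay on MGC-803 cells (Homo sapiens) for inhibition, read by MTT assay, with a stated time of 48 h; a lower number here means a stronger inhibitor, a higher number a weaker inhibitor; the only neighbour is compound 2, reached by the step of a 3.9-fold lower number from compound 1 to compound 2 (0.59 log units; beyond the scatter), which replaces the amide hydrogen by a (prop-1-en-1-yl)carbonyl group on the nitrogen.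

Compound 3, `COc1ccc(CNc2cc(OC)c(OC)c(OC)c2)cc1Br`, is the next compound to be measured. Its change from compound 1 is bromo in place of methyl on an aromatic carbon. For the measured compounds named here, no measured step in this assay bears on a change at this aromatic carbon; the single step on record concerns the nitrogen and says nothing about the substituent that sits ortho to the methoxy group. Going by the values given here, with no precedent, the expectation for compound 3 is a step no larger than the scatter, a 1.3-fold lower number from compound 1 to compound 3 (0.10 log units; within the scatter), in either direction. Compound 3 is therefore estimated at 45000 nM in this assay, with a range of 15000 nM to 130000 nM.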

Compound 3, half-maximal inhibitory concentration: 29400 nM
Compound 3: the middle estimate sits 1.5-fold (0.18 log units) above what was measured, within the range that was stated.
By their numbers in this assay, from the lowest: compound 2; then compounds 3 and 1 (each within the scatter of the next).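

In this assay, among the compounds shown here, the first reading at this aromatic carbon, ortho to a methoxy group, comes from bromo in place of methyl: a 1.9-fold lower number from compound 1 to compound 3 (0.29 log units; within the scatter), so on the core of compound 1 this exchange is not resolved from repeated measurement. For the compounds shown here, the only step beyond the scatter so far remains the change on the nitrogen, a 3.9-fold lower number from compound 1 to compound 2 (0.59 log units; beyond the scatter), and the exchange of methyl for bromo does not match it. No available evidence bears on the behaviour of this position.

On these data alone, whether an amine, a hydroxyl or a carboxylic acid on this aromatic carbon would move the number beyond the scatter remains open. Also open, as far as these compounds go, is whether bromo in place of methyl gives a similar step when the nitrogen carries the (prop-1-en-1-yl)carbonyl group of compound 2.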